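Replacing quinolin-8-yl in compound 3

The compounds below may be only part of what the source reports. "The series", "measured", "known", "first", "only" and "open" are said of these compounds alone.

compound 1 `O=C(N1CCC(c2nc(-c3ccc4ccccc4n3)no2)CC1)N1CCCc2ccccc21` gives 2300 nM
compound 2 `O=C(Nc1ccccc1C(F)(F)F)N1CCC(c2nc(-c3ccc4ccccc4n3)no2)CC1` gives 700 nM
compound 3 `O=C(Nc1cccc2cccnc12)N1CCC(c2nc(-c3ccc4ccccc4n3)no2)CC1` gives 1400 nM

All three values come from a functional assay on Shh Light II cells (Mus musculus) for inhibition, read by a luciferase reporter (a higher number here means a weaker inhibitor, a lower number a stronger inhibitor), as the read-out. Compound 3 (1400 nM) lies within the scatter of both other compounds. Compound 4 `Cc1noc(C)c1NC(=O)N1CCC(c2nc(-c3ccc4ccccc4n3)no2)CC1` carries 3,5-dimethyl-1,2-oxazol-4-yl in place of quinolin-8-yl on an amide-type nitrogen. Among the measured compounds shown here, the one measured swap on that same nitrogen was small: a 2.0-fold higher number from compound 2 to compound 3 (0.30 log units; within the scatter) is the record. Changes on the carbonyl carbon gave a 1.6-fold lower number from compound 1 to compound 3 (0.22 log units; within the scatter) and a 3.3-fold lower number from compound 1 to compound 2 (0.52 log units; beyond the scatter) as the other steps. For the measured compounds named here, no measured compound carries the entering group, so these guides are loose. The estimated step, a 1.1-fold higher number from compound 3 to compound 4 (0.03 log units; within the scatter), is expected to stay within the scatter. Compound 4 is expected at 1500 nM with an estimated range from 550 nM to 4000 nM overall.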

Compound 4, half-maximal inhibitory concentration: 3000 nM
For compound 4 the middle estimate is 2.0-fold (0.30 log units) below the measured one; low and high end bracket the measured number.
By their numbers in this assay, from the lowest: compounds 2, 3, 1 and 4 (each within the scatter of the next, the first and the last beyond it).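

In this assay, the group on the amide-type nitrogen now shows a change beyond the scatter when quinolin-8-yl leaves, with a 2.1-fold higher number from compound 3 to compound 4 (0.33 log units; beyond the scatter), and the widest step on that nitrogen so far is a 4.3-fold higher number from compound 2 to compound 4 (0.63 log units; beyond the scatter). Replacing the whole 1,2,3,4-tetrahydroquinolin-1-yl unit on the carbonyl carbon gives no clear change, with a 1.3-fold higher number from compound 1 to compound 4 (0.12 log units; within the scatter). Nothing measured here explains these differences. Still open, as far as these compounds go, is how a plain phenyl on that nitrogen would compare with the 2-(trifluoromethyl)phenyl of compound 2. A 2-methylphenyl would ask the same question of the trifluoromethyl group itself.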